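The source may hold more compounds than are shown below. What is called first, only, known or untested is meant among the compounds shown, and "the series" means these compounds.

Working notes on the arylsulfonyl series built on the shared core. In a functional assay on HeLa cells (Homo sapiens) for antiproliferative activity, read by MTT assay, with a stated time of 72 h (a lower number here means a stronger inhibitor, a higher number a weaker inhibitor), compound 1 (`N=C(NS(=O)(=O)c1ccccc1Cl)N1CCN(c2cc3c(cc2F)c(=O)c(C(=O)O)cn3C2CC2)CC1`) gives 32 nM as its reading. Compound 2 (`N=C(NS(=O)(=O)c1cccc(Cl)c1)N1CCN(c2cc3c(cc2F)c(=O)c(C(=O)O)cn3C2CC2)CC1`) gives 32 nM on the same read-out, and compound 3 (`N=C(NS(=O)(=O)c1ccc(C(F)(F)F)cc1)N1CCN(c2cc3c(cc2F)c(=O)c(C(=O)O)cn3C2CC2)CC1`) gives 32 nM as well, so compound 3 stands level with compounds 1 and 2.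

The next step leads to compound 4 (`N=C(NS(=O)(=O)c1ccc(Cl)cc1)N1CCN(c2cc3c(cc2F)c(=O)c(C(=O)O)cn3C2CC2)CC1`), which carries chloro in place of trifluoromethyl on an aromatic carbon, para to a large group: chloro in place of trifluoromethyl on an aromatic carbon is the whole difference, and cut one bond further out it reads 4-(trifluoromethyl)phenyl to 4-chlorophenyl.

Among the measured compounds shown here, three measured steps bear on this aryl group: no change at the digits printed from compound 1 to compound 2 (within the scatter) is the first, no change at the digits printed from compound 1 to compound 3 (within the scatter) the second and no change at the digits printed from compound 2 to compound 3 (within the scatter) the third. None of them goes beyond the scatter, a pattern that rests on these three compounds alone. For the measured compounds named here, no measured step isolates chloro against trifluoromethyl at this position.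

No step beyond the scatter is therefore expected in this assay and no direction is favoured, so the expected change is no change at the digits printed from compound 3 to compound 4 (within the scatter) at most in size. The estimated value for compound 4 is 32 nM with an expected range from 15 nM to 70 nM in this series.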

Compound 4, half-maximal inhibitory concentration: 32 nM
Compound 4: the middle estimate sits on the measured number at the digits printed, and the stated range covers the measured number.
By their numbers in this assay, from the lowest: compounds 1, 2, 3 and 4 (each within the scatter of the next).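

In this assay, among the compounds shown here, the swap of chloro in place of trifluoromethyl on an aromatic carbon, para to a large group, now has a direct reading, with no change at the digits printed from compound 3 to compound 4 (within the scatter) as the result; the earlier compounds offered no step that isolated these two groups at this position. Chloro can now also be compared across the aryl group, where the series gives no change at the digits printed from compound 2 to compound 4 (within the scatter) and also no change at the digits printed from compound 1 to compound 4 (within the scatter) as its readings, so 2-chlorophenyl, 3-chlorophenyl and 4-chlorophenyl all fall within the scatter of one another, and no compound among the four goes against this flat pattern. No supporting measurement bears on why these aryl changes leave the reading flat.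

From the compounds shown here alone, the four compounds cover only chloro and trifluoromethyl on the phenyl ring, so it remains open whether the flat pattern would hold with an amine, a carboxylic acid or a longer alkyl chain at the same place. Also open, going by these compounds, is whether this pattern extends to the unsubstituted phenyl group or to a replacement of the phenyl ring itself, and whether it would persist on any core other than the shared core.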